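This account rests on a few compounds, and the source may have more. Where it says the series, first, only, none or still open, it means among the compounds named here.

Of the compounds shown here, three that share one core have been tested in an ADME assay on HFF cells (Homo sapiens) for cytotoxicity, read by MTT assay, with a stated time of 72 h; a higher number here means a weaker inhibitor, a lower number a stronger inhibitor. Compound 1 `O=C1O[C@H]([C@@H](O)Cn2cc(-c3ccc(Br)cc3)nn2)C(OCc2ccccc2)=C1OCc1ccccc1` gives 5100 nM in this assay. Compound 3 `CC(C)(C)c1cn(C[C@H](O)[C@H]2OC(=O)C(OCc3ccccc3)=C2OCc2ccccc2)nn1` gives 13300 nM, the higher of the two plain numbers, set apart from compound 1 by the step of a 2.6-fold higher number from compound 1 to compound 3 (0.42 log units; beyond the scatter). For compound 2 `CCCCCc1ccc(-c2cn(C[C@H](O)[C@H]3OC(=O)C(OCc4ccccc4)=C3OCc3ccccc3)nn2)cc1` the assay reports only a limit, > 100000 nM, and this is one of the cases described by the limit of > 100000 nM in this assay, at which 1 of the 3 values shown sits.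

Compound 4 `Cc1ccc(-c2cn(C[C@H](O)[C@H]3OC(=O)C(OCc4ccccc4)=C3OCc3ccccc3)nn2)cc1` differs from compound 3 in one place: 4-methylphenyl in place of tert-butyl on an aromatic carbon. Among the measured compounds shown here, two measured steps touch this same position, each swapping tert-butyl against an aryl group. The step of a 2.6-fold higher number from compound 1 to compound 3 (0.42 log units; beyond the scatter) shows that tert-butyl in place of 4-bromophenyl raised the number, while an at least 7.5-fold lower number from compound 2 to compound 3 (0.87 log units; beyond the scatter) shows that tert-butyl in place of 4-pentylphenyl lowered it. Read backwards, an aryl group in place of tert-butyl may therefore move the number in either direction, and for 4-methylphenyl a modest change is expected: a 1.5-fold lower number from compound 3 to compound 4 (0.17 log units; within the scatter). Compound 4 is accordingly estimated at about 9000 nM, with a likely range from 2500 nM to 40000 nM.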

Compound 4, half-maximal inhibitory concentration: > 100000 nM
Compound 4: no number, only a limit (the forecaster's own chance of this, stated with the estimate: 15%); at least 11-fold (1.04 log units) between middle value and limit.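

For compound 4 in this assay, the result of > 100000 nM is a limit and not a number. Changing tert-butyl to 4-methylphenyl gives an at least 7.5-fold higher number from compound 3 to compound 4 (0.87 log units; beyond the scatter), while methyl in place of bromo on the phenyl ring gives an at least 19-fold higher number from compound 1 to compound 4 (1.29 log units; beyond the scatter), so the outcome at this position depends on what the phenyl ring carries, not only on whether a phenyl ring is present. Compound 2 with its pentyl and compound 4 with its methyl now sit at the same limit, so the step between them cannot be read: the limit of > 100000 nM in this assay, at which 2 of the 4 values shown sit.

Among the compounds with a substituted phenyl ring, only compound 1, with its bromo, gives a plain number, so one example carries that contrast. From the compounds shown here alone, whether chloro, methoxy, an amine or plain hydrogen in that place would also give a plain number remains open.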